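Methyl ester to acid on a shared core: cytotoxicity limits

A few compounds are considered here, and "the series" means these few. Any claim that something is new, unique, unknown or untested is made for them only; others in the source may bear on it.

The study measures cytotoxicity in a functional assay on SK-MEL cells (Homo sapiens) for cytotoxicity, read by MTT assay, with a stated time of 6 days; a higher number here means that more compound is needed for the effect, a lower number that less compound is needed. Compound 1, `COC(=O)c1c(-c2cc(OC)cc(OC)c2)oc2ccccc2c1=O`, is a methyl ester. In this assay compound 1 gives > 25 ug/mL, which is a limit of the assay rather than a number. Compound 3, `COc1cc(OC)cc(-c2oc3ccccc3c(=O)c2C(=O)O)c1`, differs from it by hydrogen in place of methyl on an oxygen next to a carbonyl group. In this assay compound 3 gives > 25 ug/mL, again a limit. The step between them is therefore a step that the two limits leave unreadable from compound 1 to compound 3. Compound 2, `COC(=O)c1c(-c2ccc([N+](=O)[O-])cc2)oc2ccccc2c1=O`, shares the core of compound 1, but the difference between the two cores is not broken down here. In this assay compound 2 gives > 25 ug/mL, also a limit. All three measured values sit at the same point, namely (the limit of > 25 ug/mL in this assay, at which 3 of the 3 values shown sit), so no ordering among them can be read.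

Compound 4, `O=C(O)c1c(-c2ccc([N+](=O)[O-])cc2)oc2ccccc2c1=O`, is not yet measured; it differs from compound 2 by hydrogen in place of methyl on an oxygen next to a carbonyl group, the same change as that from compound 1 to compound 3, with the same surroundings at the place. Resting on a step that the two limits leave unreadable from compound 1 to compound 3, which left both values at the limit, the expected step is a step that the limit leaves unreadable from compound 2 to compound 4, and it is most likely to stay unreadable in the same way. Compound 4 is therefore estimated at 50 ug/mL, with an expected range from 25 ug/mL to 150 ug/mL, and it will probably be reported only as a limit.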

Compound 4, concentration for half-maximal effect: > 25 ug/mL
Compound 4 was reported as a limit; the forecaster's own chance of this, stated with the estimate: 90%; the middle value lies beyond the limit too.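

With compound 2 and compound 4 both reported only as limits, the step between them cannot be read, and the change from methoxycarbonyl to carboxy gains no size here. The compounds shown leave open how much of any of them is needed for the effect in this assay, and whether this change alters it at all, since every value stands at one point: the limit of > 25 ug/mL in this assay, at which 4 of the 4 values shown sit.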